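Aryl changes on the shared core: compound 3 to compound 4

The source may report more compounds than this note shows. Statements on the series, on what has been measured and on what is new or still open speak of the compounds shown alone.

Three compounds share the core of compound 1 `COc1ccc(C2=NN(c3ccc(S(C)(=O)=O)cc3)C(=O)CC2)cc1`, which in a functional assay on the whole organism (strain Wistar) for inhibition, with Rattus norvegicus as the target, read by paw edema, with stated times of 30 min and 5 h, at a dose of 0.05 mmol/kg by the oral route (on this read-out higher numbers stand for more inhibition at the one dose given (going by the name of the read-out) and lower numbers for less inhibition), gives 68.4%. Compound 2 `Cc1cc(C2=NN(c3ccc(S(C)(=O)=O)cc3)C(=O)CC2)ccc1O` gives 60.5% in this assay, and compound 3 `CCc1ccc(C2=NN(c3ccc(S(C)(=O)=O)cc3)C(=O)CC2)cc1` gives 65.7%. Compound 3 stands second of the three, with a number 2.7 percentage points lower from compound 1 to compound 3 (within the scatter) and a number 5.2 percentage points higher from compound 2 to compound 3 (within the scatter), both steps within the scatter, so no order among the three can be claimed.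

Compound 4 `CS(=O)(=O)c1ccc(N2N=C(c3ccc(Cl)c(Cl)c3)CCC2=O)cc1` differs from compound 3 by 3,4-dichlorophenyl in place of 4-ethylphenyl on a carbon with a double bond to nitrogen. For the measured compounds named here, no measured step swaps in a 3,4-dichlorophenyl; the nearest comparisons are a number 2.7 percentage points lower from compound 1 to compound 3 (within the scatter) and a number 5.2 percentage points higher from compound 2 to compound 3 (within the scatter), each small. The expected step for compound 4 is therefore a number 1.7 percentage points lower from compound 3 to compound 4 (within the scatter), not beyond the scatter. Compound 4 is estimated at 64%, in a range from 50% to 76%.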

Compound 4, a percentage reported as inhibition, in the whole organism at one dose (the size of the read-out at that dose, not a potency): 34.2%
The estimate for compound 4 lay 29.8 percentage points above the measured number; the measured number lies below the stated range.
By their numbers in this assay, from the lowest: compound 4; then compounds 2, 3 and 1 (each within the scatter of the next).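

In this assay this position proves sensitive to the aryl group: 3,4-dichlorophenyl gives a number 31.5 percentage points lower from compound 3 to compound 4 (beyond the scatter) and likewise a number 26.3 percentage points lower from compound 2 to compound 4 (beyond the scatter) and a number 34.2 percentage points lower from compound 1 to compound 4 (beyond the scatter), whereas the three earlier aryl groups stay within the scatter of each other. Leaving 4-ethylphenyl and entering 3,4-dichlorophenyl have equal heavy-atom, donor and acceptor counts, so these counts do not separate them. Nothing measured here accounts for the drop.

On these data alone, whether 4-chlorophenyl, with a single chlorine, behaves like 3,4-dichlorophenyl remains open. So does the outcome with an amine or a carboxylic acid on the phenyl ring.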